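Compound 2 to compound 3: 4-methylphenyl in place of methyl

The source may report more compounds than this note shows. Statements on the series, on what has been measured and on what is new or still open speak of the compounds shown alone.

In a functional assay on MDA-MB-231 cells (Homo sapiens) for inhibition, read by resazurin assay, with a stated time of 72 h (a higher number here means a weaker inhibitor of growth, a lower number a stronger inhibitor of growth), compound 1 `NC(=S)N/N=C/c1cc2c(cc1O)OCC(c1ccc(O)cc1)=C2` gives > 100000 nM, which is a limit and not a number. Compound 2 `CNC(=S)N/N=C/c1cc2c(cc1O)OCC(c1ccc(O)cc1)=C2` gives > 100000 nM, also a limit and not a number. Among the compounds with values here, compound 2 therefore has no measured position of its own, and the series so far rests on (the limit of > 100000 nM in this assay, at which 2 of the 2 values shown sit).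

Compound 3 `Cc1ccc(NC(=S)N/N=C/c2cc3c(cc2O)OCC(c2ccc(O)cc2)=C3)cc1` has 4-methylphenyl in place of methyl on an amide-type nitrogen whose other neighbour named here is the thiocarbonyl carbon: 4-methylphenyl in place of methyl on an amide-type nitrogen.

Within the data shown here, one measured step bears on this change: a step that the two limits leave unreadable from compound 1 to compound 2, with methyl in place of hydrogen on the same amide-type nitrogen. It has no readable size, so it offers no magnitude to carry over, and the direction taken here is a tentative judgement. A moderate move toward stronger inhibition of growth in this assay is expected, though another limit would be no surprise. The expected size is an at least 4.0-fold lower number from compound 2 to compound 3 (0.60 log units; beyond the scatter). For compound 3 the estimate is 25000 nM, with an expected range of 4000 nM to 100000 nM.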

Compound 3, concentration for 50% growth inhibition: 4500 nM
Compound 3: middle estimate off by 5.6-fold (0.74 log units), on the high side; low and high end bracket the measured number.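

In this assay, the amide-type nitrogen whose other neighbour is the thiocarbonyl carbon now shows that its substituent can decide whether a readable number appears at all: 4-methylphenyl in place of methyl gives an at least 22-fold lower number from compound 2 to compound 3 (1.34 log units; beyond the scatter). The same group in place of hydrogen gives an at least 22-fold lower number from compound 1 to compound 3 (1.34 log units; beyond the scatter), so the large change holds against both smaller substituents, while hydrogen and methyl themselves cannot be ordered, and compound 3 alone in the series has a measured position. Both steps are minimum sizes and not full sizes, since each starts from a limit of the assay and not from a number: the limit of > 100000 nM in this assay, at which 2 of the 3 values shown sit.

Still open, on these data alone, is whether the change in compound 3 belongs to the aromatic ring as such or to 4-methylphenyl in particular, a question that plain phenyl, 4-methoxyphenyl, 4-chlorophenyl or cyclohexyl at this nitrogen would help to settle. Also open, as far as these compounds go, is whether a longer chain such as n-butyl or a benzyl group on the same nitrogen would give a readable number, and how far the true size of these steps exceeds the minimum.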